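Swapping a Methylamino for a Tert-butyl on the Aniline Ring

This account rests on a few compounds, and the source may have more. Where it says the series, first, only, none or still open, it means among the compounds named here.

Of the compounds shown here, three sharing a common core have been measured in a functional assay for inhibition, with Homo sapiens as the target; on this read-out lower numbers stand for stronger inhibition and higher numbers for weaker inhibition. Compound 1, `CNc1ccc(Nc2nccc(-c3cccnc3)n2)cc1`, gives 2100 nM. Compound 2, `CC1CCN(c2ccc(Nc3nccc(-c4cccs4)n3)cc2)CC1`, gives 400 nM, and compound 3, `COc1cccc(Nc2nccc(-c3cc4ccccc4o3)n2)c1`, gives 2800 nM. Among these three numbers, compound 1 stands second highest: its number lies close to that of compound 3, within the usual scatter, while compound 2 stands clearly apart with a lower number that lies beyond the scatter.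

The next compound to be measured is compound 4, `CC(C)(C)c1ccc(Nc2nccc(-c3cccnc3)n2)cc1`. It differs from compound 1 in a single place: tert-butyl in place of methylamino on an aromatic carbon. The new group sits on an aromatic carbon of a six-membered aromatic ring of carbon only, para to a large group.

Within the data shown here, no measured pair in this set differs in exactly this way, so the size of the step is open. Compound 2, which also carries a larger group in that position, gives the lowest number seen, which hints that the direction could be toward stronger inhibition. The expected step from compound 1 to compound 4 in this assay is a modest one, a 1.5-fold lower number from compound 1 to compound 4 (0.18 log units; within the scatter), likely within or barely beyond the scatter. Compound 4 is therefore estimated at 1400 nM, with a range from 400 nM to 5000 nM.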

Compound 4, half-maximal inhibitory concentration: 600 nM
Beside the measured number, compound 4's estimate is 2.3-fold (0.37 log units) above it; the measured number falls inside the stated range.
By their numbers in this assay, from the lowest: compounds 2 and 4 (each within the scatter of the next); then compounds 1 and 3 (each within the scatter of the next).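

In this assay, among these compounds, putting tert-butyl in place of methylamino on this aromatic carbon gives a 3.5-fold lower number from compound 1 to compound 4 (0.54 log units; beyond the scatter), the first step in this set between two compounds that differ in one place. It shows that the group at this position can change the number with the rest of compound 1 held constant, and that the lower number in compound 4 does not need the hydrogen-bond donor or acceptor counted on methylamino. Nothing available here explains why the number falls with this change.

The compounds shown leave open whether the step follows the larger group or the loss of the nitrogen, a question that isopropyl or dimethylamino on the same carbon could help separate. Among the compounds shown here, they also leave open whether the same swap would give a similar step with the thiophene-free parts of the molecule changed, since only this one pair can be read.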